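The source may report more compounds than this note shows. Statements on the series, on what has been measured and on what is new or still open speak of the compounds shown alone.

Compound 1 `CCCSc1nc(N/N=C(\C)c2ccccc2O)c2nnn(Cc3ccccc3Cl)c2n1` gives > 64000 nM in a functional assay on ECa-109 cells (Homo sapiens) for antiproliferative activity, read by MTT assay, with a stated time of 72 h; a lower number here means a stronger inhibitor, a higher number a weaker inhibitor.
Compound 2 `CCCSc1nc(N/N=C/c2ccc([N+](=O)[O-])cc2)c2nnn(Cc3ccccc3)c2n1` gives 6640 nM in this assay.

The number for compound 1 is a limit of this assay and not a measured value: the limit of > 64000 nM in this assay, at which 1 of the 2 values shown sits. Compound 1 therefore sits at the weak end of the two values shown. Within the data shown here, compound 2 differs from compound 1 in more than one place, so the two values show only that compound 2 has a measured number where compound 1 has none.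

Compound 3 `CCCSc1nc(N/N=C(\C)c2ccccc2O)c2nnn(Cc3ccco3)c2n1` has not yet been tested in this assay. It differs from compound 1 by furan-2-yl in place of 2-chlorophenyl on a saturated chain carbon bound to an aromatic nitrogen. Among the measured compounds shown here, no step between measured compounds is available, so the expected size of the step from compound 1 to compound 3 rests on compound 1 alone. With compound 1 at the limit (the limit of > 64000 nM in this assay, at which 1 of the 2 values shown sits), the expectation is no change beyond the scatter, and compound 3 will most likely also be reported as a limit; the expected step is a step that the limit leaves unreadable from compound 1 to compound 3. Compound 3 is expected to give about 70000 nM, in a range from 15000 nM to 250000 nM.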

Compound 3, half-maximal inhibitory concentration: 5760 nM
Beside the measured number, compound 3's estimate is 12-fold (1.08 log units) above it; the measured number lies below the stated range.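

Among these compounds, compounds 1 and 2 differ in more than one place, so they could not single out any position, but here only one group changes, furan-2-yl in place of 2-chlorophenyl, and the result is an at least 11-fold lower number from compound 1 to compound 3 (1.04 log units; beyond the scatter) in this assay. This shows that the group on a saturated chain carbon bound to an aromatic nitrogen can, by itself, take the core of compound 1 from a limit to a measured number. The starting point of the step is a limit held by compound 1: the limit of > 64000 nM in this assay, at which 1 of the 3 values shown sits.

The change swaps the chlorine, the ring size and the ring oxygen all at once, so the compounds shown cannot say which of these matters. They also leave open how thiophen-2-yl, pyridin-2-yl or a morpholine at this position would read.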